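Replacing a sulfur-linked benzimidazole group with chloro

The source may report more compounds than this note shows. Statements on the series, on what has been measured and on what is new or still open speak of the compounds shown alone.

In a functional assay on A549 cells (Homo sapiens) for cytotoxicity, read by MTT assay, with a stated time of 72 h (a lower number here means a stronger inhibitor, a higher number a weaker inhibitor), compound 1 (`C=C1C2=C(C(=O)N1OC)[C@H](OC(=O)CSc1nc3ccccc3s1)[C@@](C)(O)[C@H](CCCCC)O2`) gives 5900 nM and compound 2 (`C=C1C2=C(C(=O)N1OC)[C@H](OC(=O)CSc1nc3ccccc3[nH]1)[C@@](C)(O)[C@H](CCCCC)O2`) gives 19000 nM as the higher, weaker number of the two. Among the compounds with values here, the only measured step is a 3.2-fold higher number from compound 1 to compound 2 (0.51 log units; beyond the scatter) (modest but beyond the usual scatter), with 1H-benzimidazol-2-yl in place of 1,3-benzothiazol-2-yl on a sulfur. Compound 3 (`C=C1C2=C(C(=O)N1OC)[C@H](OC(=O)CCl)[C@@](C)(O)[C@H](CCCCC)O2`) changes more (chloro in place of (1H-benzimidazol-2-yl)sulfanyl on a saturated chain carbon bound to a carbonyl carbon). Within the data shown here, no measured compound lacks the sulfur-linked group, so that single step is only a loose guide to the size of this change. A modest move toward a lower number is expected because compound 2 stands at 19000 nM (the top of the two values). The expected change is a 2.1-fold lower number from compound 2 to compound 3 (0.32 log units; beyond the scatter) and it remains uncertain. For compound 3 the estimated value is 9000 nM (expected range 2500 nM to 30000 nM).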

Compound 3, half-maximal inhibitory concentration: 20000 nM
The estimate for compound 3 lay 2.2-fold (0.35 log units) below the measured number; the measured number falls inside the stated range.
By their numbers in this assay, from the lowest: compound 1; then compounds 2 and 3 (each within the scatter of the next).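

In this assay, the change to chloro on a saturated chain carbon bound to a carbonyl carbon gives a 1.1-fold higher number from compound 2 to compound 3 (0.02 log units; within the scatter), so losing the whole (1H-benzimidazol-2-yl)sulfanyl group, both aromatic rings included, makes no readable difference. The (1,3-benzothiazol-2-yl)sulfanyl group of compound 1 does stand apart from chloro, with a 3.4-fold higher number from compound 1 to compound 3 (0.53 log units; beyond the scatter), so among these three compounds only that group goes with a lower number. No evidence is available on the reason for this result.

Still open, as far as these compounds go, is whether a simple amine at this place would match chloro, or whether a sulfur-linked phenyl ring would match compound 1. A sulfur-linked benzoxazole would also help show how much of the gap follows the fused ring system's own atoms.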